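Urea series at the urotensin receptor: compound 3 to compound 4

The source may hold more compounds than are shown below. What is called first, only, known or untested is meant among the compounds shown, and "the series" means these compounds.

Compound 3 `O=C(NCCN1CCC(O)(Cc2ccccc2)CC1)Nc1ccnc2c(Br)csc12` gives the highest number of the three measured compounds: in an assay on HEK293 cells for displacement of a labelled ligand from Urotensin-2 receptor (Homo sapiens) (a lower number here means a stronger inhibitor, a higher number a weaker inhibitor), compound 3 gives 3220 nM. The nearest neighbour is compound 2 `O=C(NCCN1CCC(O)(Cc2ccccc2)CC1)Nc1ccnc2ccoc12`, which gives 450 nM; the furthest is compound 1 `Cn1ccc2c(NC(=O)NCCN3CCC(O)(Cc4ccccc4)CC3)ccnc21`, which gives 160 nM. Both steps into compound 3 are beyond the scatter: a 7.2-fold higher number from compound 2 to compound 3 (0.85 log units; beyond the scatter) and a 20-fold higher number from compound 1 to compound 3 (1.30 log units; beyond the scatter).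

Compound 4 `O=C(NCCN1CCC(O)(Cc2ccccc2)CC1)Nc1ccnc2sccc12` differs from compound 3 only on the bicyclic attached to the urea: a group of 9 heavy atoms (7 carbon, 1 nitrogen, 1 sulfur; one five-membered aromatic ring with 1 hetero atom, one six-membered aromatic ring with 1 hetero atom) in place of a group of 10 heavy atoms (7 carbon, 1 nitrogen, 1 sulfur, 1 bromine; one five-membered aromatic ring with 1 hetero atom, one six-membered aromatic ring with 1 hetero atom), on an amide-type nitrogen. Going by the values given here, no measured step removes a bromine from this bicyclic, so the size of the expected change rests on the bicyclic exchanges alone. The step of a 7.2-fold higher number from compound 2 to compound 3 (0.85 log units; beyond the scatter) shows that the brominated sulfur bicyclic gave a clearly weaker compound than the oxygen bicyclic, and a 20-fold higher number from compound 1 to compound 3 (1.30 log units; beyond the scatter) shows the same against compound 1. For compound 4, a lower number than compound 3 is expected, roughly back toward compound 2, giving an expected step of a 4.6-fold lower number from compound 3 to compound 4 (0.66 log units; beyond the scatter). The estimate for compound 4 is 700 nM, within 250 nM to 2500 nM.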

Compound 4, half-maximal inhibitory concentration: 930 nM
For compound 4 the middle estimate is 1.3-fold (0.12 log units) below the measured one; low and high end bracket the measured number.
By their numbers in this assay, from the lowest: compound 1; then compound 2; then compound 4; then compound 3.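

Removing the bromine is not the whole story at this amide-type nitrogen: in this assay the sulfur bicyclic of compound 4 recovers part of the loss, with a 3.5-fold lower number from compound 3 to compound 4 (0.54 log units; beyond the scatter) as the step, yet it does not reach the other two bicyclics. The remaining gaps, a 2.1-fold higher number from compound 2 to compound 4 (0.32 log units; beyond the scatter) and a 5.8-fold higher number from compound 1 to compound 4 (0.76 log units; beyond the scatter), are both printed as beyond the scatter, so among these four compounds the unbrominated sulfur bicyclic ranks third, ahead of compound 3 only. Nothing available here bears on the reason for these steps.

From the compounds shown here alone, the step from compound 3 exchanges one whole bicyclic for another, so the share of the bromine alone stays open. In this assay, going by these compounds, it also remains open how a chlorine or a methyl group in place of the bromine would compare with compound 3 and compound 4.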